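The source may report more compounds than this note shows. Statements on the series, on what has been measured and on what is new or still open speak of the compounds shown alone.

The study concerns two measured compounds and one that awaits measurement. Compound 1 `CCCc1nc(-c2ccccc2)c(CNCCCN2CCN(c3cccc(C(F)(F)F)c3)CC2)o1` gives 51.6% in an assay on HEK293 cells for inhibition of Voltage-dependent T-type calcium channel subunit alpha-1G (Homo sapiens), read by fluorescence, tested at 10 uM (a higher number here means more inhibition at the concentration tested (going by the name of the read-out), a lower number less inhibition), the higher of the two values recorded there. Going by the values given here, compound 2 `Cc1nc(-c2ccccc2)c(CNCCCN2CCN(c3ccc(Cl)cc3)CC2)o1` gives 38.1% in this assay, a value that lies beyond the scatter below that of compound 1; since the two compounds differ in more than one place, no single step links them, and only their two numbers can be compared. Compound 3 `CCCc1nc(-c2ccccc2)c(CNCCCN2CCN(c3cccc(Cl)c3)CC2)o1` has not yet been tested in this assay. It differs from compound 1 in one place: chloro in place of trifluoromethyl on an aromatic carbon. Among the compounds with values here, no measured pair in this set isolates that change, so the expectation rests on the value of compound 1 alone and on the general experience that such a swap seldom moves a single-concentration read-out far. The expected change is a number 7.6 percentage points lower from compound 1 to compound 3 (within the scatter), a small move downward that may well stay within the scatter. Compound 3 is therefore expected to give 44% in this assay, with a likely range from 25% to 62%.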

Compound 3, a percentage reported as inhibition, at one concentration (the size of the read-out at that concentration, not a potency): 65.9%
Compound 3: middle estimate off by 21.9 percentage points, on the low side; the whole stated range lies below it.
By their numbers in this assay, from the lowest: compound 2; then compound 1; then compound 3.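

In this assay, chloro in place of trifluoromethyl on this aromatic carbon, meta to a large group, gives a number 14.3 percentage points higher from compound 1 to compound 3 (beyond the scatter). The earlier compounds shown here could not show this, as compound 1 and compound 2 differ in more than one place, whereas compound 1 and compound 3 differ only in this group, so the read-out is now seen to respond to a change at this position alone. Nothing at hand accounts for the step, and this single pair, in which the group of one heavy atom gives the higher number than the group of four, sets no trend.

The compounds shown leave open whether a fluoro, methoxy or nitrile group at this position would give a number nearer to that of compound 1 or to that of compound 3. They also leave open whether the same swap would give a step of similar size on the core of compound 2, and how far this single-concentration difference would carry over to a difference in potency.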